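The source may hold more compounds than are shown below. What is called first, only, known or untested is meant among the compounds shown, and "the series" means these compounds.

Measured in a functional assay on HT-29 cells (Homo sapiens) for cytotoxicity, read by MTT assay, with a stated time of 6 days; on this read-out lower numbers stand for an effect already at smaller amounts and higher numbers for an effect only at larger amounts of compound:
Compound 1 `COC(=O)c1c(-c2ccc(OC)cc2)oc2ccccc2c1=O`: > 25 ug/mL, a limit of the assay and not a number
Compound 2 `COc1cc(-c2cc(=O)c3cc(O)ccc3o2)cc(OC)c1OC`: 7.85 ug/mL
Compound 3 `COc1cc(-c2cc(=O)c3ccc(O)c(O)c3o2)cc(OC)c1OC`: 3.66 ug/mL

Of the two true numbers in this assay, the lower belongs to compound 3 at 3.66 ug/mL. The higher belongs to compound 2 at 7.85 ug/mL, and the gap between them lies beyond the usual scatter.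

The account now moves to compound 4 `COc1cc(-c2cc(=O)c3ccc(O)c(O)c3o2)cc(OC)c1O[Si](C)(C)C(C)(C)C`, which differs from compound 3 in one place: a group of 7 heavy atoms (6 carbon, 1 silicon; no ring) in place of one carbon atom, on an oxygen on an aromatic ring. A methyl leaves an oxygen on an aromatic ring, and a larger group with silicon and no ring takes its place.

Among the measured compounds shown here, no measured pair here shows a change of this kind, so the expectation is loose. It starts from compound 3 at 3.66 ug/mL. In this assay a step within the scatter is expected, leaning toward a higher number. The estimate implies an expected step of a 1.5-fold higher number from compound 3 to compound 4 (0.18 log units; within the scatter). For compound 4 the expected value is 5.5 ug/mL, with an estimated range of 1.5 ug/mL to 20 ug/mL.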

Compound 4, concentration for half-maximal effect: 0.34 ug/mL
Compound 4: middle estimate off by 16-fold (1.21 log units), on the high side, outside the stated range (below it).
By their numbers in this assay, from the lowest: compound 4; then compound 3; then compound 2. At a limit, above all of these: compound 1.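

In this assay, among the compounds shown here, putting the larger silicon-bearing group on an oxygen on an aromatic ring in place of the methyl gives an 11-fold lower number from compound 3 to compound 4 (1.03 log units; beyond the scatter), and this large step is the first single-place change. Compound 2 and compound 3 both carry a methyl at this oxygen, so only now is it clear that the group there can be exchanged for a much larger one without the number rising, and that this one change can lower it far beyond the scatter. Nothing measured here bears on why the number falls so far.

The compounds shown leave open whether silicon itself matters, or whether an all-carbon group such as a longer chain on the same oxygen would give a similar number. They also leave open what a free hydroxyl at this place would give.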